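Swapping the saturated ring for its unsaturated form

This account rests on a few compounds, and the source may have more. Where it says the series, first, only, none or still open, it means among the compounds named here.

Three compounds share a long unsaturated chain that carries an aryl ether at one end and a five-membered oxygen ring at the other. Compound 1 `C/C(=C\COc1c(Cl)cccc1Cl)CC/C=C(\C)C1CC(=O)C(C)(C)O1` carries a dichlorophenyl ether and gives 50.5 ug/mL in a functional assay (Homo sapiens) for inhibition; on this read-out higher numbers stand for weaker inhibition and lower numbers for stronger inhibition. Compound 3 `C/C(=C\COc1c(Cl)cccc1Cl)CC/C=C(\C)C1=CC(=O)C(C)(C)O1` keeps that ether but has a double bond inside the ring; in this assay compound 3 gives 27.4 ug/mL. Compound 2 `C/C(=C\COc1ccc2ccccc2c1)CC/C=C(\C)C1CC(=O)C(C)(C)O1` combines the saturated ring with a naphthyl ether, and in this assay compound 2 gives 26.9 ug/mL, the lowest of the three numbers, though all three lie within the scatter of one another.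

Compound 4 `C/C(=C\COc1ccc2ccccc2c1)CC/C=C(\C)C1=CC(=O)C(C)(C)O1` is the untested partner of compound 2: a group of 8 heavy atoms (6 carbon, 2 oxygen; one five-membered non-aromatic ring with 1 hetero atom) in place of a group of 8 heavy atoms (6 carbon, 2 oxygen; one five-membered non-aromatic ring with 1 hetero atom), on a double-bonded chain carbon bound to a double-bonded chain carbon and a saturated chain carbon. For the measured compounds named here, the only measured step of this kind is a 1.8-fold lower number from compound 1 to compound 3 (0.27 log units; within the scatter), which is not a change that can be told apart from noise. With a single comparison, on a different ether, the expectation for compound 4 in this assay is therefore a small lowering or no real change, written as a 1.5-fold lower number from compound 2 to compound 4 (0.17 log units; within the scatter). The estimate for compound 4 is 18 ug/mL, with a likely range from 8 ug/mL to 40 ug/mL.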

Compound 4, half-maximal inhibitory concentration: 51.6 ug/mL
Compound 4: the middle estimate sits 2.9-fold (0.46 log units) below what was measured, outside the stated range (above it).
By their numbers in this assay, from the lowest: compounds 2, 3, 1 and 4 (each within the scatter of the next).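

Placing a double bond inside the ring, in the change that removes 5,5-dimethyl-4-oxooxolan-2-yl, gives in this assay a 1.9-fold higher number from compound 2 to compound 4 (0.28 log units; within the scatter), which on its own cannot be told apart from noise. Its real weight comes from comparison with the same ring change on the dichlorophenyl ether, where the number moved the opposite way, so in these four compounds the ring change has no single effect that carries over from one ether to the other: the same change on two cores in this assay, a 1.8-fold lower number (0.27 log units; within the scatter) from compound 1 to compound 3 and a 1.9-fold higher number (0.28 log units; within the scatter) from compound 2 to compound 4, 3.5-fold (0.55 log units) apart, beyond the scatter of two such steps. Neither step is beyond the scatter by itself, so the finding rests only on the gap between the two steps, and what can be said about this position is that the outcome of changing the ring depends on the ether it is paired with.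

With only two ethers and two ring forms, the compounds shown cannot say why the pairing matters or whether the reversal would hold on a third ether. A matched pair of saturated and unsaturated rings carrying a plain phenyl ether or an aryl ether bearing a carboxylic acid would show whether the split between the two steps extends beyond these four compounds.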